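This account rests on a few compounds, and the source may have more. Where it says the series, first, only, none or still open, it means among the compounds named here.

Measured so far in a physicochemical assay for solubility, in phosphate buffer; a lower number here means a less soluble compound, a higher number a more soluble compound:
Compound 1 `CCCCCCc1ccc(C(=O)CCN2CCC(C(=O)OC)CC2)cc1`: 27000 nM
Compound 2 `CCCCCCc1ccc(C(=O)/C=C\C(=O)O)cc1`: 252000 nM
Compound 3 `C/C=C/C(=O)c1ccc(CCCCCCC)cc1`: 41000 nM

Compound 2 has the highest number of the three, and its gaps to compound 1 and compound 3 both lie beyond the scatter. Compound 4 `CCCCCCc1ccc(C(=O)C2CO2)cc1` has oxiran-2-yl in place of 2-carboxyethenyl on a carbonyl carbon. For the measured compounds named here, no step between measured compounds covers this change, so the expectation rests on the three values alone. Only compound 2 carries 2-carboxyethenyl, and compound 4 will lack it, as do the two measured compounds with lower numbers. Compound 3 gives 41000 nM and compound 1 gives 27000 nM, and these two are the nearest guide. They differ from compound 4 in other ways too, so the guide is weak. The expected step is a 5.6-fold lower number from compound 2 to compound 4 (0.75 log units; beyond the scatter), a fall beyond the scatter in this assay. For compound 4 the estimated value is 45000 nM, with an expected range of 18000 nM to 110000 nM.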

Compound 4, solubility: 204000 nM
For compound 4 the middle estimate is 4.5-fold (0.66 log units) below the measured one, and the stated range ends below it.
By their numbers in this assay, from the lowest: compounds 1 and 3 (each within the scatter of the next); then compounds 4 and 2 (each within the scatter of the next).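

In this assay, oxiran-2-yl in place of 2-carboxyethenyl on a carbonyl carbon comes with a 1.2-fold lower number from compound 2 to compound 4 (0.09 log units; within the scatter), so this pair gives no separation between the two groups at this position. The high reading of compound 2 is therefore not tied to 2-carboxyethenyl: compound 4 reaches the same range with oxiran-2-yl, a smaller group of 3 heavy atoms with a three-membered ring and 0 hydrogen-bond donors. Nothing measured here explains why two such different groups read alike.

This single pair cannot show whether the match extends to other groups on the same carbonyl carbon, such as a saturated 2-carboxyethyl group, a primary amide or a cyclopropyl ring. Cyclopropyl would also test whether the oxygen of the three-membered ring matters for this read-out.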